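Chloro for Fluoro on a Second Oxadiazole Core

This account rests on a few compounds, and the source may have more. Where it says the series, first, only, none or still open, it means among the compounds named here.

Compound 1 `N#Cc1ccc(OCc2nnc(-c3ccc(F)cc3)o2)cc1F` and compound 2 `N#Cc1ccc(OCc2nnc(-c3ccc(Cl)cc3)o2)cc1F` share one core and differ by a single change, (chloro in place of fluoro on an aromatic carbon). In a functional assay on MCF7 cells (Homo sapiens) for cytotoxicity, read by MTT assay, with a stated time of 48 h (a higher number here means a weaker inhibitor, a lower number a stronger inhibitor), compound 1 gives 20500 nM, and compound 2 gives 48300 nM, so the change produced a 2.4-fold higher number from compound 1 to compound 2 (0.37 log units; beyond the scatter). Compound 3 `Fc1ccc(-c2nnc(COc3ccc(-c4nnco4)cc3)o2)cc1` is built on a core whose difference from that of compound 1 is not broken down here; in this assay compound 3 gives 35600 nM, which lies within the usual scatter of the values of compound 1 and compound 2. Compound 4 `Clc1ccc(-c2nnc(COc3ccc(-c4nnco4)cc3)o2)cc1` carries the same change on the core of compound 3, (chloro in place of fluoro on an aromatic carbon), at a place described in identical words. Resting only on the step seen between compound 1 and compound 2, the step from compound 3 to compound 4 is expected to be about a 2.0-fold higher number from compound 3 to compound 4 (0.29 log units; within the scatter), so compound 4 is estimated at 70000 nM, between 30000 nM and 170000 nM.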

Compound 4, half-maximal inhibitory concentration: 45200 nM
For compound 4 the middle estimate is 1.5-fold (0.19 log units) above the measured one; measured number inside the range.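

Replacing 4-fluorophenyl with 4-chlorophenyl on the core of compound 3 gives a 1.3-fold higher number from compound 3 to compound 4 (0.10 log units; within the scatter) in this assay. Set beside the earlier step on the core of compound 1, this step cannot be told apart from it: the same change on two cores in this assay, a 2.4-fold higher number (0.37 log units; beyond the scatter) from compound 1 to compound 2 and a 1.3-fold higher number (0.10 log units; within the scatter) from compound 3 to compound 4, 1.9-fold (0.27 log units) apart, within the scatter of two such steps. The two steps are therefore compatible with the change carrying over between these cores, but they do not prove that it does, since only the first lies beyond the scatter and each core offers a single pair.

The compounds shown carry only fluoro or chloro at this place, so the effect of bromo, methoxy or an amine there remains open. As far as these compounds go, whether the step would hold on a third core also remains open.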